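From 4-isopropylpiperazin-1-yl to a carbonyl-bearing piperidine

The source may report more compounds than this note shows. Statements on the series, on what has been measured and on what is new or still open speak of the compounds shown alone.

In an in vitro ADME assay on microsomes (Mus musculus) for metabolic stability, read by LC-MS, with a stated time of 15 min (on this read-out lower numbers stand for a shorter-lived compound and higher numbers for a longer-lived compound), compound 1 (`CC(C)Nc1nc(-c2ccc(NC(=O)Nc3ccc(N4CCN(C)CC4)cc3)cc2)nc(N2C3CCC2COC3)n1`) gives > 0.5 h, a limit and not a number. Compound 2 (`CCN1CCN(c2ccc(NC(=O)Nc3ccc(-c4nc(C5CCOCC5)nc(N5C6CCC5COC6)n4)cc3)cc2)CC1`) gives > 0.5 h, again a limit. Compound 3 (`CC(C)N1CCN(c2ccc(NC(=O)Nc3ccc(-c4nc(C5CCOCC5)nc(N5C6CCC5COC6)n4)cc3)cc2)CC1`) gives > 0.5 h, also a limit, so the record so far is the limit of > 0.5 h in this assay, at which 3 of the 3 values shown sit. Compound 4 (`CN(C)C1CCN(C(=O)c2ccc(NC(=O)Nc3ccc(-c4nc(C5CCOCC5)nc(N5C6CCC5COC6)n4)cc3)cc2)CC1`) carries (4-(dimethylamino)piperidin-1-yl)carbonyl in place of 4-isopropylpiperazin-1-yl on an aromatic carbon. Going by the values given here, the only measured step that bears on this change is a step that the two limits leave unreadable from compound 2 to compound 3, and it offers no size to carry over. No change beyond the scatter is therefore expected, and the estimated step is a number no higher from compound 3 to compound 4 (the limit leaves the size open). Compound 4 is estimated at 0.5 h, with an expected range of 0.2 h to 1 h.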

Compound 4, half-life: > 0.5 h
Compound 4 gave a limit, no number; the forecaster's own chance of this, stated with the estimate: 70%; the middle value sits exactly at the limit.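

In this assay compound 4 gives > 0.5 h, a limit and not a number, so the steps to compound 4 from compound 2 and compound 3 cannot be read. The compounds shown leave open what the actual half-lives are, and whether (4-(dimethylamino)piperidin-1-yl)carbonyl in place of 4-isopropylpiperazin-1-yl changes the half-life at all.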